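Pyrazin-2-yl in place of 1,3-thiazol-2-yl on an oxygen

A few compounds are considered here, and "the series" means these few. Any claim that something is new, unique, unknown or untested is made for them only; others in the source may bear on it.

Of the compounds shown here, three have been measured in an ADME assay on the whole organism (Rattus norvegicus) for pharmacokinetics, using cassette dosing, at a dose of 1 mg/kg by the oral route; a higher number here means that a larger share of the oral dose reaches the circulation, a lower number that a smaller share of the oral dose reaches the circulation. Compound 1 `Cc1ccc(Cn2c(=O)n(CC(C)(C)C(=O)O)c(=O)[nH]/c2=N\c2ccc(OC(C)C)c(Cl)c2)cc1` gives 30.7%, compound 2 `CC(C)Oc1ccc(/N=c2\[nH]c(=O)n(C[C@@H](C)C(=O)O)c(=O)n2Cc2ccc(Cl)cc2)cc1Cl` gives 108%, and compound 3 `C[C@@H](Cn1c(=O)[nH]/c(=N\c2ccc(Oc3nccs3)cc2)n(Cc2ccc(Cl)cc2)c1=O)C(=O)O` gives 41.4%. Compound 3 therefore stands second highest of the three, above compound 1 and far under compound 2, with both gaps beyond the usual scatter.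

Compound 4 `C[C@@H](Cn1c(=O)[nH]/c(=N\c2ccc(Oc3cnccn3)cc2)n(Cc2ccc(Cl)cc2)c1=O)C(=O)O` has not yet been measured. It differs from compound 3 in one place: pyrazin-2-yl in place of 1,3-thiazol-2-yl on an oxygen on an aromatic ring. Going by the values given here, no two measured compounds differ in only one place, so the data offer no direct precedent for this change, and the wide spread among the three values argues for a broad range. Among the compounds with values here, with no such step to lean on, the expectation starts from compound 3 at 41.4%. The step of a number 3.6 percentage points higher from compound 3 to compound 4 (within the scatter) is expected to stay within the scatter, with no clear direction. In this assay the estimated value for compound 4 is 45%, within an expected range of 20% to 75%.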

Compound 4, oral bioavailability: 56.5%
Compound 4: middle estimate off by 11.5 percentage points, on the low side, within the range that was stated.
By their numbers in this assay, from the lowest: compound 1; then compound 3; then compound 4; then compound 2.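

Exchanging the 1,3-thiazol-2-yl on the oxygen for pyrazin-2-yl shows, in this assay, a number 15.1 percentage points higher from compound 3 to compound 4 (beyond the scatter), a modest step. Going by these compounds alone, this is the first comparison in which only one place differs, and it shows that the ring on this oxygen can by itself move the share of the oral dose reaching the circulation beyond the scatter. That step comes with a five-membered aromatic ring giving way to a six-membered one, while the count of hydrogen-bond acceptors stays the same, but nothing shown accounts for it.

On these data alone, whether a plain phenyl or a pyridin-2-yl on the same oxygen would give a similar number remains open. So does whether the step would carry over to a compound with another acid chain or another benzyl group.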